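A few compounds are considered here, and "the series" means these few. Any claim that something is new, unique, unknown or untested is made for them only; others in the source may bear on it.

Measured so far in a functional assay on MDA-MB-231 cells (Homo sapiens) for cytotoxicity, read by MTT assay, with a stated time of 48 h; a higher number here means a weaker inhibitor, a lower number a stronger inhibitor:
- compound 1 `COc1cc(N2C(=S)SCC2(O)c2ccc(Br)cc2)cc(OC)c1OC` gives 15.1 ug/mL
- compound 2 `COc1cc(N2C(=S)SCC2(O)c2ccc(Cl)cc2Cl)cc(OC)c1OC` gives 14.5 ug/mL
- compound 3 `COc1cc(-n2c(-c3ccc(Cl)cc3Cl)csc2=S)cc(OC)c1OC` gives 49 ug/mL

Of these three, compound 3 has the highest number, and a higher number here marks a weaker inhibitor. Compound 1 and compound 2 both lie lower than compound 3, beyond the usual scatter of repeat measurements. The next compound, compound 4 `COc1cc(-n2c(-c3ccc(O)cc3)csc2=S)cc(OC)c1OC`, keeps the core of compound 3 and changes a single group: 4-hydroxyphenyl in place of 2,4-dichlorophenyl on an aromatic carbon of a five-membered aromatic ring with 1 nitrogen and 1 sulfur.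

Among the measured compounds shown here, only one measured step swaps a group of this kind: a 1.0-fold lower number from compound 1 to compound 2 (0.02 log units; within the scatter), with 2,4-dichlorophenyl in place of 4-bromophenyl on a saturated ring carbon. For the measured compounds named here, that step sits on a different core, and no measured compound carries 4-hydroxyphenyl, so the guidance is thin. It does show a swap of this kind that left the number within the scatter. Since compound 3 at 49 ug/mL is already the highest of the three, a small drop looks slightly likelier than a rise, but no step beyond the scatter is expected in this assay. The expected step is a 1.4-fold lower number from compound 3 to compound 4 (0.15 log units; within the scatter), and this estimate is uncertain. For compound 4 the estimated value is 35 ug/mL, with an expected range from 13 ug/mL to 90 ug/mL.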

Compound 4, half-maximal inhibitory concentration: 22.9 ug/mL
Compound 4: the middle estimate sits 1.5-fold (0.18 log units) above what was measured; the range from low to high includes it.
By their numbers in this assay, from the lowest: compounds 2, 1 and 4 (each within the scatter of the next); then compound 3.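

In this assay the aromatic carbon next to the ring nitrogen of the five-membered aromatic ring with 1 nitrogen and 1 sulfur proves sensitive to the group it carries: replacing 2,4-dichlorophenyl with 4-hydroxyphenyl gives a 2.1-fold lower number from compound 3 to compound 4 (0.33 log units; beyond the scatter) and makes compound 4 a modestly stronger inhibitor than compound 3. The only earlier swap of this kind, on a saturated ring carbon of a different core, gave a 1.0-fold lower number from compound 1 to compound 2 (0.02 log units; within the scatter), so this is the first group change shown here to move the number beyond the scatter. Nothing available explains why the number fell at this position.

The change removes both chlorine atoms and adds a hydroxy group in one step, so the compounds shown cannot separate the effect of the loss from that of the addition, and a plain phenyl group at this position would help to pull the two apart. From the compounds shown here alone, whether the hydroxy group itself matters also stays open, and 4-methoxyphenyl or 4-aminophenyl in the same place would test that directly.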